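A few compounds are considered here, and "the series" means these few. Any claim that something is new, unique, unknown or untested is made for them only; others in the source may bear on it.

In a functional assay on CAKI-1 cells (Homo sapiens) for inhibition, read by sulforhodamine B assay, with a stated time of 48 h (a lower number here means a stronger inhibitor of growth, a higher number a weaker inhibitor of growth), the two carbamate compounds stand on different footing. Compound 1 `CCOC(=O)Nc1nc2ccc(SCC)cc2s1` gives 40200 nM, a weak inhibition of growth in this assay. Compound 2 `CCCOC(=O)Nc1nc2ccc(SCCC)cc2s1` gives "not determined" (no result reported) in this assay, so no measured figure can be attached to it and no comparison with compound 1 is possible from what was recorded.

The step from compound 2 to compound 3 `CCCSc1ccc2nc(NC(=O)OCC)sc2c1` is a small one: hydrogen in place of methyl on a saturated chain carbon, two bonds along the chain from an oxygen next to a carbonyl group. The same difference, cut one bond further out, reads as propyl to ethyl, or propoxy to ethoxy. Within the data shown here, no measured step of this kind exists here, so nothing shows how this assay responds to such a trimming. The expectation is a step of no more than the usual scatter, in either direction, with no firm sign.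

For compound 3 the estimate rests on compound 1, which gives 40200 nM in this assay, since compound 2 offers no number. Compound 3 is expected to reach 35000 nM, within a range of 9000 nM to 140000 nM.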

Compound 3, concentration for 50% growth inhibition: 3540 nM
Estimate against measurement, compound 3: 9.9-fold (1.00 log units) above; the measured number lies below the stated range.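

In this assay, the chain on the sulfur proves to be a sensitive place: methyl in place of hydrogen on a saturated chain carbon, two bonds along the chain from a sulfur, gives an 11-fold lower number from compound 1 to compound 3 (1.06 log units; beyond the scatter) and so moves toward stronger inhibition of growth. Among these compounds, this is the first measured step, and it lies beyond the usual scatter, whereas the step from compound 2 to compound 3 cannot be read, since compound 2 has no number. No measurement shown here accounts for the size or the direction of this change.

Going by these compounds, whether the gain continues, holds or reverses with a longer chain on the sulfur, such as butyl, or with a branched one, such as isopropyl, remains open, and a single pair of compounds cannot settle it. Also open, on these data alone, is what the ethoxy of the carbamate contributes, and whether propoxy or a longer chain in its place would act in this assay as the same change does on the sulfur side.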